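Swapping a hydroxymethyl for a carboxy on a shared core

The source may hold more compounds than are shown below. What is called first, only, known or untested is meant among the compounds shown, and "the series" means these compounds.

Compound 1 `O=C(CCl)Nc1cccc(Cn2nc(-c3ccc(Oc4ccccc4)cc3)cc2CO)c1` is the reference point here. Going by the values given here, in a functional assay on Maver1 cells (Homo sapiens) for inhibition, read by luminescence and CellTiter-Glo, with a stated time of 72 h (on this read-out higher numbers stand for weaker inhibition and lower numbers for stronger inhibition), compound 1 gives 400 nM, the lowest of the two numbers measured so far. Among the compounds with values here, its only measured neighbour is compound 2 `C/C=C/C(=O)Nc1cccc(Cn2nc(-c3ccc(Oc4ccccc4)cc3)cc2CO)c1`, which in this assay gives 8100 nM; that step, a 20-fold higher number from compound 1 to compound 2 (1.31 log units; beyond the scatter), changes the group on the carbonyl carbon, and it is a large one.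

The compound not yet measured is compound 3 `O=C(CCl)Nc1cccc(Cn2nc(-c3ccc(Oc4ccccc4)cc3)cc2C(=O)O)c1`. It differs from compound 1 in carboxy in place of hydroxymethyl on an aromatic carbon. Within the data shown here, this change sits far from the carbonyl that was altered between compound 1 and compound 2, so the one measured step does not speak to it directly; no measured pair shows what exchanging these two groups on the five-membered ring does in this assay.

Among the measured compounds shown here, without a guiding step, a moderate weakening is expected rather than none, because the only other change seen, a 20-fold higher number from compound 1 to compound 2 (1.31 log units; beyond the scatter), showed how sensitive this read-out can be. For compound 3 the expected step is a 3.8-fold higher number from compound 1 to compound 3 (0.57 log units; beyond the scatter). Compound 3 is therefore estimated at 1500 nM, with a range from 300 nM to 8000 nM.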

Compound 3, half-maximal inhibitory concentration: 4700 nM
Compound 3: the middle estimate sits 3.1-fold (0.50 log units) below what was measured; the measured number falls inside the stated range.
By their numbers in this assay, from the lowest: compound 1; then compounds 3 and 2 (each within the scatter of the next).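

In this assay the hydroxymethyl on the five-membered aromatic ring proves not to be a freely exchangeable group: with the chloromethyl carbonyl part held fixed, carboxy in its place gives a 12-fold higher number from compound 1 to compound 3 (1.07 log units; beyond the scatter) and so clearly weaker inhibition. Until now only the group on the carbonyl carbon had been seen to matter, through a 20-fold higher number from compound 1 to compound 2 (1.31 log units; beyond the scatter) and its loss of inhibition, whereas this result shows that a second, separate place on the shared core also moves the read-out, and compound 1 keeps the lowest number of the three. Nothing available here accounts for why this exchange weakens inhibition.

What the compounds shown leave open is whether any other group at this place would do as well as hydroxymethyl or better, such as a methyl ester, a primary amide, an aminomethyl group or a plain methyl. They also leave open whether carboxy would cost as much alongside the prop-1-en-1-yl carbonyl of compound 2, since that combination does not appear among them.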